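The compounds below may be only part of what the source reports. "The series", "measured", "known", "first", "only" and "open" are said of these compounds alone.

Measured compounds:
compound 1 `Nc1ccccc1NC(=O)c1ccc(CSC(=S)N2CCN(Cc3ccccn3)CC2)cc1` — 23.4%
compound 2 `CN1CCN(C(=S)SCc2ccc(C(=O)Nc3ccccc3N)cc2)CC1` — 29.6%
compound 3 `Nc1ccccc1NC(=O)c1ccc(CSC(=S)N2CCN(c3ncccn3)CC2)cc1` — 28.4%

In a functional assay on MGC-803 cells (Homo sapiens) for antiproliferative activity, read by CCK-8 assay, with a stated time of 72 h, tested at 2 uM (on this read-out lower numbers stand for a weaker effect and higher numbers for a stronger effect at the one concentration tested), compound 3 stands second highest of the three numbers. Its nearest neighbour is compound 2, which in this assay gives 29.6%, and the step of a number 1.2 percentage points lower from compound 2 to compound 3 (within the scatter) is within the scatter. Compound 1 in this assay gives 23.4%, and the step of a number 5 percentage points higher from compound 1 to compound 3 (within the scatter) is also within the scatter, as is a number 6.2 percentage points higher from compound 1 to compound 2 (within the scatter). All three substituents on the ring nitrogen therefore give much the same number.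

Compound 4 `Nc1ccccc1NC(=O)c1ccc(CSC(=S)N2CCN(Cc3cccnc3)CC2)cc1` differs from compound 3 by (pyridin-3-yl)methyl in place of pyrimidin-2-yl on an amine nitrogen in a ring. The nearest measured step is a number 5 percentage points higher from compound 1 to compound 3 (within the scatter), since compound 1 carries the (pyridin-2-yl)methyl group, and it was within the scatter. No step beyond the scatter is expected; compound 4 is estimated at 25%, range 12% to 38%, meaning an expected step of a number 3.4 percentage points lower from compound 3 to compound 4 (within the scatter).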

Compound 4, a percentage reported as inhibition, at one concentration (the size of the read-out at that concentration, not a potency): 37.7%
The estimate for compound 4 lay 12.7 percentage points below the measured number; measured number inside the range.
By their numbers in this assay, from the lowest: compounds 1, 3, 2 and 4 (each within the scatter of the next, the first and the last beyond it).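

In this assay, going by these compounds alone, pyridin-3-yl in place of pyridin-2-yl on the saturated chain carbon gives (a number 14.3 percentage points higher from compound 1 to compound 4 (beyond the scatter)), the only step in this set beyond the scatter, so the point of attachment on the pyridine ring can register at this position where the earlier changes on the ring nitrogen did not. The other two steps (a number 9.3 percentage points higher from compound 3 to compound 4 (within the scatter)) and (a number 8.1 percentage points higher from compound 2 to compound 4 (within the scatter)) stay within the scatter, so compound 4 separates from compound 1 alone. Nothing available explains this difference. As far as these compounds go, whether pyridin-4-yl on the same chain carbon or a longer chain bearing pyridin-3-yl would move the number further remains open.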